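Swapping the Fluorophenyl Amide for a Pyridyl Amide

The source may hold more compounds than are shown below. What is called first, only, known or untested is meant among the compounds shown, and "the series" means these compounds.

Compound 1 `COc1ccc(NC(=O)C2CCN(C/C=C/c3ccccc3)CC2)cc1` and compound 2 `O=C(Nc1cccc(F)c1)C1CCN(C/C=C/c2ccccc2)CC1` share one core and differ only in the ring attached to the amide-type nitrogen. In a functional assay on MGC-803 cells (Homo sapiens) for inhibition, read by MTT assay, with a stated time of 72 h (a lower number here means a stronger inhibitor, a higher number a weaker inhibitor), compound 1 gives 58200 nM, while compound 2 gives 23300 nM. The step between them is a 2.5-fold lower number from compound 1 to compound 2 (0.40 log units; beyond the scatter). Going by the values given here, compound 2 therefore holds the lower of the two numbers, and its only neighbour, compound 1, is separated from it by that same modest step.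

Compound 3 `O=C(Nc1ccccn1)C1CCN(C/C=C/c2ccccc2)CC1` is the next variation on the same position: pyridin-2-yl in place of 3-fluorophenyl on an amide-type nitrogen. Among the compounds with values here, the single measured step bears on it only loosely, since it shows that exchanging one ring for another on the amide-type nitrogen moved the number by a modest amount, yet neither measured compound carries a ring with a hetero atom, so nothing shows how a pyridin-2-yl behaves here. The expectation is a step of similar modest size or none beyond the scatter, direction uncertain. Compound 3 is thus estimated at 30000 nM, with a range from 10000 nM to 90000 nM, meaning an expected step of a 1.3-fold higher number from compound 2 to compound 3 (0.11 log units; within the scatter).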

Compound 3, half-maximal inhibitory concentration: 45200 nM
For compound 3 the middle estimate is 1.5-fold (0.18 log units) below the measured one; the measured number falls inside the stated range.
By their numbers in this assay, from the lowest: compounds 2, 3 and 1 (each within the scatter of the next, the first and the last beyond it).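

The first ring with a hetero atom on this amide-type nitrogen leaves this assay without a clear separation from either phenyl compound: pyridin-2-yl in place of 3-fluorophenyl gives a 1.9-fold higher number from compound 2 to compound 3 (0.29 log units; within the scatter) and pyridin-2-yl in place of 4-methoxyphenyl gives a 1.3-fold lower number from compound 1 to compound 3 (0.11 log units; within the scatter). The two phenyl compounds do stand apart (a 2.5-fold lower number from compound 1 to compound 2 (0.40 log units; beyond the scatter)), so compound 3 fits with each of them yet does not show which of the two it resembles more, and this one change cannot be ranked as better or worse than either ring. Nothing among the data offers a reason for these numbers, and no independent measurement of any property of the three rings is available to connect with them.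

On these data alone, the three compounds speak only to aromatic rings of six atoms on this nitrogen, so it stays open how pyridin-3-yl or pyridin-4-yl would compare with pyridin-2-yl, and how a saturated cyclohexyl or a benzyl group would read here. As far as these compounds go, a carboxylic acid or an amine on the ring is equally open, as is any change to the rest of the shared core, which is identical in all three compounds.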